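A few compounds are considered here, and "the series" means these few. Any claim that something is new, unique, unknown or untested is made for them only; others in the source may bear on it.

Three analogues sharing one core have been measured in a functional assay on HCC827 cells (Homo sapiens) for antiproliferative activity, read by MTT assay, with a stated time of 72 h; a higher number here means a weaker inhibitor, a lower number a stronger inhibitor. Compound 1 `CN1CCN(c2ccc(Nc3ncc4nc(Nc5ccc(F)cc5)n([C@H]5CCN(C(=O)CO)C5)c4n3)cc2)CC1` gives 380 nM, compound 2 `CC(=O)N1CC[C@H](n2c(Nc3ccccc3)nc3cnc(Nc4ccc(N5CCN(C)CC5)cc4)nc32)C1` gives 260 nM, and compound 3 `CN1CCN(c2ccc(Nc3ncc4nc(Nc5ccc(F)cc5)n([C@@H]5CCCC(NC(=O)OC(C)(C)C)C5)c4n3)cc2)CC1` gives 280 nM. Compound 1 carries the highest of the three numbers, yet its gaps to compound 2 and to compound 3 both lie within the scatter, so no order among the three can be read from them. Compound 4 `CN1CCN(c2ccc(Nc3ncc4nc(Nc5ccc(F)cc5)n([C@H]5CCN(S(=O)(=O)C6CC6)C5)c4n3)cc2)CC1` has not been measured. It differs from compound 1 as cyclopropylsulfonyl in place of (hydroxymethyl)carbonyl on an amine nitrogen in a ring. For the measured compounds named here, no measured pair in this set shows that change, so nothing here fixes its size. The expected step in this assay is a 1.2-fold lower number from compound 1 to compound 4 (0.07 log units; within the scatter), no larger than the scatter, with no direction favoured. Compound 4 is accordingly estimated at 320 nM, in the range 110 nM to 950 nM.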

Compound 4, half-maximal inhibitory concentration: 7.5 nM
Estimate against measurement, compound 4: 43-fold (1.63 log units) above; the measured number lies below the stated range.
By their numbers in this assay, from the lowest: compound 4; then compounds 2, 3 and 1 (each within the scatter of the next).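

In this assay cyclopropylsulfonyl in place of (hydroxymethyl)carbonyl on the ring amine nitrogen brings a 51-fold lower number from compound 1 to compound 4 (1.70 log units; beyond the scatter) and so shows that this position can strongly change the number. The earlier compounds shown here, all within the scatter of each other, gave no sign of this. No measurement shown here explains the step.

Open, on these data alone, is whether the sulfonyl link or the cyclopropyl ring carries the step; methylsulfonyl or cyclopropylcarbonyl on the same nitrogen would separate the two. Also open, as far as these compounds go, is whether the step holds when the 4-fluorophenyl group on the core is replaced.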